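A few compounds are considered here, and "the series" means these few. Any claim that something is new, unique, unknown or untested is made for them only; others in the source may bear on it.

Compounds measured in an ADME assay on Vero 76 cells (Chlorocebus sabaeus) for cytotoxicity, read by MTT assay, with a stated time of 96 h; on this read-out lower numbers stand for higher toxicity in this test and higher numbers for lower toxicity in this test:

compound 1, `NS(=O)(=O)c1ccc(N2N=C(c3ccc(Oc4ccccc4)cc3)CC2c2ccccc2F)cc1`: 96000 nM
compound 2, `NS(=O)(=O)c1ccc(N2N=C(c3ccccc3)CC2c2ccccc2F)cc1`: 28000 nM
compound 3, `NS(=O)(=O)c1ccc(N2N=C(c3ccc(OCc4ccccc4)cc3)CC2c2ccccc2F)cc1`: > 100000 nM

Among the measured compounds shown here, the value of compound 3 is a limit of this assay, not a number; it is the one value that sits at the limit of > 100000 nM in this assay, at which 1 of the 3 values shown sits.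

Among the two numbers, compound 1 stands highest; the nearest is compound 2, reached by a 3.4-fold lower number from compound 1 to compound 2 (0.54 log units; beyond the scatter), a change of hydrogen in place of phenoxy on an aromatic carbon. The step to compound 3, an at least 1.0-fold higher number from compound 1 to compound 3 (0.01 log units; that floor lies within the scatter), changes benzyl in place of phenyl on an oxygen on an aromatic ring and can only be read against the limit. The step of an at least 3.5-fold higher number from compound 2 to compound 3 (0.55 log units; beyond the scatter) likewise ends at the limit.

Compound 4, `NS(=O)(=O)c1ccc(N2N=C(c3ccc(Oc4ccccc4)cc3)CC2c2cccc(Cl)c2)cc1`, differs from compound 1 by 3-chlorophenyl in place of 2-fluorophenyl on a saturated ring carbon. For the measured compounds named here, all three measured steps concern the group on the aromatic carbon or on its oxygen; none changes the group on the saturated ring carbon, so no measured step bears directly on this change. The numbers give no ground for expecting a step beyond the scatter in either direction in this assay.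

Compound 4 is therefore expected at about 100000 nM, within 40000 nM to 250000 nM, meaning an expected step of a 1.0-fold higher number from compound 1 to compound 4 (0.02 log units; within the scatter).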

Compound 4, half-maximal cytotoxic concentration: 88000 nM
Compound 4: middle estimate off by 1.1-fold (0.06 log units), on the high side, and the stated range covers the measured number.
By their numbers in this assay, from the lowest: compound 2; then compounds 4 and 1 (each within the scatter of the next). At a limit, above all of these: compound 3.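

Among the compounds shown here, this is the first measured change at the saturated ring carbon next to the ring nitrogen: in this assay, 3-chlorophenyl in place of 2-fluorophenyl gives a 1.1-fold lower number from compound 1 to compound 4 (0.04 log units; within the scatter). With the phenoxy group kept, this position therefore accepts a change in both the halogen and its place on the phenyl ring without leaving the scatter, whereas removing the phenoxy group at the other end of the molecule gave a 3.4-fold lower number from compound 1 to compound 2 (0.54 log units; beyond the scatter), so among the steps shown, only the group on the aromatic carbon has moved the read-out beyond the scatter. Nothing measured here gives a cause for the step at the saturated ring carbon.

From the compounds shown here alone, it remains open whether 3-chlorophenyl would give the same result with hydrogen or benzyloxy in place of phenoxy, since this change has been read only against the phenoxy compounds. Also open, going by these compounds, is how this assay responds when this position carries something other than a halogen-bearing phenyl ring, such as a phenyl ring with an amine or a carboxylic acid on it, or a longer alkyl chain in place of the ring.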